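The source may report more compounds than this note shows. Statements on the series, on what has been measured and on what is new or still open speak of the compounds shown alone.

Measured compounds and their values in a functional assay on HCT-116 cells (Homo sapiens) for inhibition, read by MTT assay, with a stated time of 2 days, tested at 10 uM; on this read-out higher numbers stand for more inhibition at the one concentration tested (going by the name of the read-out) and lower numbers for less inhibition:
compound 1 `COc1ccc(OC)c(-c2cn(-c3ccc(O)c(C(=O)Nc4cccc(C(F)(F)F)c4)c3)nn2)c1` gives 46%
compound 2 `COc1ccc(-c2cn(-c3ccc(O)c(C(=O)O)c3)nn2)cc1` gives 8%
compound 3 `COC(=O)c1cc(-n2cc(-c3ccc(OC)cc3)nn2)ccc1O` gives 6%

Compound 3 stands lowest of the three; its gap to compound 2 is within the scatter, while compound 1 lies far above it. Among the compounds with values here, the only single step seen so far, a number 2 percentage points lower from compound 2 to compound 3 (within the scatter), changes nothing of note. The move to compound 4 `COc1ccc(-c2cn(-c3ccc(O)c(C(=O)Nc4cccc(C(F)(F)F)c4)c3)nn2)cc1` is different: (3-(trifluoromethyl)phenyl)amino in place of methoxy on a carbonyl carbon. Within the data shown here, no measured step tests this exact change, but compound 1, which carries the same (3-(trifluoromethyl)phenyl)amino group on its carbonyl, gives 46%. A clear rise beyond the scatter is therefore expected, a number 32 percentage points higher from compound 3 to compound 4 (beyond the scatter). Compound 4 is estimated at 38%, within 18% to 58%.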

Compound 4, a percentage reported as inhibition, at one concentration (the size of the read-out at that concentration, not a potency): 9%
Compound 4: middle estimate off by 29 percentage points, on the high side, outside the stated range (below it).
By their numbers in this assay, from the lowest: compounds 3, 2 and 4 (each within the scatter of the next); then compound 1.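

In this assay, (3-(trifluoromethyl)phenyl)amino on the carbonyl carbon does not raise the number when 4-methoxyphenyl is present, whether it replaces methoxy (a number 3 percentage points higher from compound 3 to compound 4 (within the scatter)) or hydroxy (a number 1 percentage points higher from compound 2 to compound 4 (within the scatter)). The large difference instead lies in the aryl group, with 4-methoxyphenyl in place of 2,5-dimethoxyphenyl on an aromatic carbon (a number 37 percentage points lower from compound 1 to compound 4 (beyond the scatter)). Nothing available explains this.

Going by these compounds, it remains open whether 2,5-dimethoxyphenyl would give a similar number with a carboxylic acid or methyl ester on the carbonyl carbon. A smaller group there, such as methylamino, is also untested among the compounds shown.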